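The source may report more compounds than this note shows. Statements on the series, on what has been measured and on what is new or still open speak of the compounds shown alone.

Of the compounds shown here, three from one series have been tested in a functional assay on A549 cells (Homo sapiens) for cytotoxicity, read by MTT assay; on this read-out lower numbers stand for stronger inhibition and higher numbers for weaker inhibition. Compound 1, `N#Cc1c(F)c(Cl)c2nc(N)nc(N)c2c1F`, gives 30.8 ug/mL in this assay. Compound 2, `N#Cc1c(N)c(Cl)c2nc(N)nc(N)c2c1Cl`, gives 188 ug/mL. Compound 3, `COc1ccc(Nc2c(C#N)c(F)c3c(N)nc(N)nc3c2Cl)cc1`, gives 103 ug/mL. Among these three numbers compound 3 stands second highest: its nearest neighbour is compound 2, whose number is within the scatter of that of compound 3, while compound 1 lies furthest away, with a lower number that falls beyond the scatter.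

The account now follows a single change applied to compound 3. The new compound, compound 4, is `CC(C)(C)Nc1c(C#N)c(F)c2c(N)nc(N)nc2c1Cl`; it differs from compound 3 in one respect only, (tert-butyl in place of 4-methoxyphenyl on a nitrogen on an aromatic ring). Among the measured compounds shown here, no pair of measured compounds shows that same exchange, so there is no measured step to lean on, and what can be said about compound 4 must rest on the three numbers above and on the nature of the substitution.

The expectation is a small step in this assay, within the usual scatter of repeated measurements, from compound 3 to compound 4, expressed as a 1.1-fold higher number from compound 3 to compound 4 (0.03 log units; within the scatter). Compound 4 is therefore estimated at 110 ug/mL in this assay, with a likely range from 40 ug/mL to 300 ug/mL.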

Compound 4, half-maximal inhibitory concentration: 313 ug/mL
The estimate for compound 4 lay 2.8-fold (0.45 log units) below the measured number; the whole stated range lies below it.
By their numbers in this assay, from the lowest: compound 1; then compounds 3, 2 and 4 (each within the scatter of the next, the first and the last beyond it).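

In this assay the substituent on a nitrogen on an aromatic ring turns out to matter: tert-butyl in place of 4-methoxyphenyl gives a 3.0-fold higher number from compound 3 to compound 4 (0.48 log units; beyond the scatter) and so a modest step beyond the scatter, the only exchange at this place among the compounds shown. Among the compounds shown here, the second step gives a wider view, as (tert-butyl)amino in place of fluoro on an aromatic carbon gives a 10-fold higher number from compound 1 to compound 4 (1.01 log units; beyond the scatter) and this large step is the biggest gap so far. The compounds shown offer no measurement that would explain either step.

The leaving group carries a six-membered aromatic ring and an oxygen while the entering group has neither, so these two compounds cannot tell which of those differences accounts for the step. Going by these compounds, it also remains open how the number would respond on that same nitrogen to a plain phenyl, a benzyl or a cyclohexyl group, any of which would help to separate the contribution of the ring from that of the methoxy group.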